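Replacing a sulfonylamino group with 4-nitrophenyl in compound 3

The source may report more compounds than this note shows. Statements on the series, on what has been measured and on what is new or still open speak of the compounds shown alone.

Compound 1 `CC1=CC[C@H]2[C@H](CC[C@]2(C)O)C(C)(C)[C@@H]1CC[C@H]1[C@]2(C)CC[C@H](OC(=O)c3ccccc3)C(C)(C)O[C@H]2CC[C@@]1(C)O`: 16100 nM
Compound 2 `CC1=CC[C@H]2[C@H](CC[C@]2(C)O)C(C)(C)[C@@H]1CC[C@H]1[C@]2(C)CC[C@H](OC(=O)NS(=O)(=O)c3ccc(C)cc3)C(C)(C)O[C@H]2CC[C@@]1(C)O`: 47100 nM

In a functional assay on MDA-MB-231 cells (Homo sapiens) for antiproliferative activity, read by MTT assay, with a stated time of 72 h (on this read-out higher numbers stand for weaker inhibition and lower numbers for stronger inhibition), compound 2, at 47100 nM, has the higher of the two numbers, which makes it the weaker inhibitor. Compound 3 `CC1=CC[C@H]2[C@H](CC[C@]2(C)O)C(C)(C)[C@@H]1CC[C@H]1[C@]2(C)CC[C@H](OC(=O)c3ccc([N+](=O)[O-])cc3)C(C)(C)O[C@H]2CC[C@@]1(C)O` differs from it as follows: 4-nitrophenyl in place of ((4-methylphenyl)sulfonyl)amino on a carbonyl carbon. Like compound 1, compound 3 therefore has a phenyl-type group on that carbonyl carbon. Within the data shown here, the one measured step that bears on this is a 2.9-fold higher number from compound 1 to compound 2 (0.47 log units; beyond the scatter), a modest rise on introducing the same ((4-methylphenyl)sulfonyl)amino group. Removing that group is expected to reverse the rise, giving a 2.5-fold lower number from compound 2 to compound 3 (0.39 log units; beyond the scatter). The estimate for compound 3 is 19000 nM, with an expected range of 7000 nM to 45000 nM.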

Compound 3, half-maximal inhibitory concentration: 8900 nM
For compound 3 the middle estimate is 2.1-fold (0.33 log units) above the measured one; low and high end bracket the measured number.
By their numbers in this assay, from the lowest: compounds 3 and 1 (each within the scatter of the next); then compound 2.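

In this assay there is a 5.3-fold lower number from compound 2 to compound 3 (0.72 log units; beyond the scatter) when 4-nitrophenyl replaces ((4-methylphenyl)sulfonyl)amino on this carbonyl carbon, so the sulfonylamino group is the poorer of the two here. Adding the nitro group to the phenyl ring gives a 1.8-fold lower number from compound 1 to compound 3 (0.26 log units; within the scatter) and so makes no clear difference at this ring position. As far as these compounds go, it remains open whether an aromatic ring is needed on this carbonyl carbon at all, or whether a simple methyl group or an amine would serve equally well. No accompanying measurement explains these differences.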